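Swapping an aryl group for a flexible ether chain

The compounds below may be only part of what the source reports. "The series", "measured", "known", "first", "only" and "open" are said of these compounds alone.

Among the measured compounds shown here, compound 1, `Cc1nn(-c2ncnc3nc[nH]c23)c2c1C(c1ccc(OC(C)C)cc1)CC(=O)N2`, is the stronger of the two compounds measured so far in a functional assay on HEK293 cells for agonist activity at G-protein coupled receptor 39 (Homo sapiens), read by scintillation proximity assay and inositol phosphate accumulation, with a stated time of 75 min, in the presence of a further agent that is not named here (a lower number here means that less compound is needed, a higher number that more compound is needed for the effect), where compound 1 gives 18 nM. Compound 2, `C=CCN1c2c(n(C)c(=O)n(C)c2=O)NC1N/N=C/c1ccc(O)cc1O`, shares no ready comparison with it beyond the numbers themselves: in this assay compound 2 gives 340 nM, a gap that lies beyond the usual scatter. The next compound, compound 3, `Cc1nn(-c2ncnc3nc[nH]c23)c2c1C(OCCc1ccccc1)CC(=O)N2`, keeps the core of compound 1 but carries a different group on a saturated ring carbon: phenethyloxy in place of 4-isopropoxyphenyl on a saturated ring carbon. Nothing measured yet shows how this kind of swap plays out, so the expectation rests on compound 1 alone. Because compound 1 sits at 18 nM, a step from compound 1 to compound 3 of an 8.3-fold higher number from compound 1 to compound 3 (0.92 log units; beyond the scatter) toward a higher number is expected. Compound 3 is estimated at 150 nM, with a range from 30 nM to 1000 nM.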

Compound 3, half-maximal effective concentration: 3 nM
For compound 3 the middle estimate is 50-fold (1.70 log units) above the measured one, and the stated range ends above it.
By their numbers in this assay, from the lowest: compound 3; then compound 1; then compound 2.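

On the saturated ring carbon of the shared core, phenethyloxy does more than stand in for 4-isopropoxyphenyl: in this assay the swap gives a 6.0-fold lower number from compound 1 to compound 3 (0.78 log units; beyond the scatter), so less compound is needed for the effect. Among the compounds shown here, this is the first comparison in which only this one place differs, and it shows that the position does not need a benzene ring attached directly to the ring carbon, since a ring carried on an ether chain also works here. For the compounds shown here, nothing measured so far explains the lower number.

The swap changes the link to the ring carbon, the length of the chain and the isopropoxy ending together, and the compounds shown do not separate these. On these data alone, it also remains open how an amine, a carboxylic acid or a longer chain at this carbon would compare.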